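The compounds below may be only part of what the source reports. "The series", "measured", "known", "first", "only" and "open" are said of these compounds alone.

Compound 1 `O=C(NCc1ccc(F)cc1)c1nc(Br)c2cccnc2c1NCc1ccc(F)cc1` is the reference here. In a functional assay on HCT-116 cells (Homo sapiens) for cytotoxicity, read by MTT assay, with a stated time of 72 h (a higher number here means a weaker inhibitor, a lower number a stronger inhibitor), compound 1 gives only a limit, > 20000 nM, not a measured number. Compound 2 `N[C@H]1CC[C@H](NC(=O)c2nc(Br)c3cccnc3c2NCc2ccc(F)cc2)CC1` gives 6400 nM in this assay, and compound 3 `CS(=O)(=O)NCCCN(c1nc(C(=O)NCc2ccc(F)cc2)c(O)c2ncccc12)S(C)(=O)=O` gives 15000 nM. For the measured compounds named here, the single measured step from the reference, an at least 3.1-fold lower number from compound 1 to compound 2 (0.49 log units; beyond the scatter), shows that replacing a 4-fluorobenzyl with an amine-bearing group lowered the number, though because compound 1 sits at the limit of > 20000 nM in this assay, at which 1 of the 3 values shown sits, the true size of that step is uncertain. Compound 4 `NCCCCCCNc1c(C(=O)NCc2ccc(F)cc2)nc(Br)c2cccnc12` makes an analogous change on the other nitrogen of the shared core: 5-aminopentyl in place of 4-fluorophenyl on a saturated chain carbon bound to a nitrogen on an aromatic ring. A step of similar size and direction is expected, an at least 2.5-fold lower number from compound 1 to compound 4 (0.39 log units; beyond the scatter). Compound 4 is therefore estimated to give about 8000 nM in this assay, within a range from 3000 nM to 20000 nM.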

Compound 4, half-maximal inhibitory concentration: 7000 nM
Compound 4: the middle estimate sits 1.1-fold (0.06 log units) above what was measured; the range from low to high includes it.
By their numbers in this assay, from the lowest: compounds 2 and 4 (each within the scatter of the next); then compound 3. At a limit, above all of these: compound 1.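

Swapping 4-fluorophenyl for 5-aminopentyl, on a saturated chain carbon bound to a nitrogen on an aromatic ring, also lowers the number in this assay: an at least 2.8-fold lower number from compound 1 to compound 4 (0.45 log units; beyond the scatter). The earlier amine-bearing change sat on an amide-type nitrogen, so this lower number is no longer confined to that one place, and here the incoming group has no ring. The true size of the step remains unknown because compound 1 sits at a limit: the limit of > 20000 nM in this assay, at which 1 of the 4 values shown sits.

On these data alone, the amine's own part remains open, since this change also removes the aromatic ring. A plain hexyl chain, a hydroxyl or carboxylic acid at the chain end, or a shorter or longer aminoalkyl chain would help separate these effects.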